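Swapping a Methylphenyl Arm for a Fluorophenyl One

A few compounds are considered here, and "the series" means these few. Any claim that something is new, unique, unknown or untested is made for them only; others in the source may bear on it.

Compound 1, `Cc1ccnc(NC(c2ccccc2C)c2ccc3cccnc3c2O)c1`, gives > 10000 nM in a functional assay on U-87MG ATCC cells for inhibition, with U-87 MG (Homo sapiens) as the target, read by MTT assay, with a stated time of 72 h; a higher number here means a weaker inhibitor, a lower number a stronger inhibitor.
Compound 2, `Oc1cc2c(cc1C(c1ccc(F)cc1)N1CCCCC1)CCC2`, gives 13000 nM in this assay.
Compound 3, `Cc1ccc(C(Nc2ccccn2)c2ccc3cccnc3c2O)cc1`, gives > 10000 nM in this assay.

The value for compound 1 is a limit of the assay, not a number: it sits at the limit of > 10000 nM in this assay, at which 2 of the 3 values shown sit. The value for compound 3 is likewise a limit. For the measured compounds named here, compound 2 is the only one with a number, and that number lies in the weak range. On the numbers shown, then, compound 1 stands among weak inhibitors, and no step between two measured compounds differing in a single place is available to guide the next move.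

Compound 4, `Cc1ccnc(NC(c2ccc(F)cc2)c2ccc3cccnc3c2O)c1`, differs from compound 1 in one place: 4-fluorophenyl in place of 2-methylphenyl on a saturated chain carbon bound to an aromatic carbon and a nitrogen on an aromatic ring. With every value shown either weak or at a limit, the step from compound 1 to compound 4 is expected to be none beyond the usual scatter, and a step that the limit leaves unreadable from compound 1 to compound 4 is the estimated step. Compound 4 is therefore expected to give about 15000 nM in this assay, with a likely range from 6000 nM to 40000 nM, and most probably only a limit will be reported.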

Compound 4, half-maximal inhibitory concentration: > 10000 nM
Compound 4 was reported as a limit (the forecaster's own chance of this, stated with the estimate: 70%); the middle value is on the limit's open side.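

Compound 1 and compound 4 are both reported only as limits, not numbers, so no step can be read between them: the limit of > 10000 nM in this assay, at which 3 of the 4 values shown sit.

The compounds shown leave open whether 4-fluorophenyl in place of 2-methylphenyl changes inhibition at all in this assay.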